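This account rests on a few compounds, and the source may have more. Where it says the series, first, only, none or still open, it means among the compounds named here.

Compound 1 `COc1ccc([C@@H]2CC(=O)c3c(O)cc(OCc4cn(Cc5cccc(Cl)c5)nn4)cc3O2)cc1O` gives 18200 nM in a functional assay on RAW264.7 cells (Mus musculus) for inhibition, read by Griess assay, with stated times of 2 h and 24 h; on this read-out higher numbers stand for weaker inhibition and lower numbers for stronger inhibition.
Compound 2 `COc1ccc([C@@H]2CC(=O)c3c(O)cc(OCc4cn(CC5CC5)nn4)cc3O2)cc1O` gives 11900 nM in this assay.
Compound 3 `COc1ccc([C@@H]2CC(=O)c3c(O)cc(OCc4cn(Cc5ccc(C)cc5)nn4)cc3O2)cc1O` gives 16800 nM in this assay.

Compound 3 stands second highest of these three numbers; its nearest neighbour is compound 1 and its furthest is compound 2, and both steps, a 1.1-fold lower number from compound 1 to compound 3 (0.03 log units; within the scatter) and a 1.4-fold higher number from compound 2 to compound 3 (0.15 log units; within the scatter), lie within the scatter, so no order among the three can be read from them. Compound 4 `CCn1cc(COc2cc(O)c3c(c2)O[C@H](c2ccc(OC)c(O)c2)CC3=O)nn1` is not yet measured. It differs from compound 3 in one place: methyl in place of 4-methylphenyl on a saturated chain carbon bound to an aromatic nitrogen. Within the data shown here, the closest precedent is the step of a 1.4-fold higher number from compound 2 to compound 3 (0.15 log units; within the scatter), where cyclopropyl and 4-methylphenyl were exchanged on the same saturated chain carbon bound to an aromatic nitrogen with no shift beyond the scatter; a 1.5-fold lower number from compound 1 to compound 2 (0.18 log units; within the scatter) and a 1.1-fold lower number from compound 1 to compound 3 (0.03 log units; within the scatter) were likewise within the scatter. All three swaps at this position left the number essentially unchanged, so the expected step in this assay, a 1.2-fold lower number from compound 3 to compound 4 (0.08 log units; within the scatter), stays within the scatter. For compound 4 a value of 14000 nM is estimated, with a range from 6500 nM to 30000 nM.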

Compound 4, half-maximal inhibitory concentration: 15000 nM
Compound 4: middle estimate off by 1.1-fold (0.03 log units), on the low side; the range from low to high includes it.
By their numbers in this assay, from the lowest: compounds 2, 4, 3 and 1 (each within the scatter of the next).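

Compound 4 has methyl where compound 3 has 4-methylphenyl on the saturated chain carbon bound to an aromatic nitrogen, so the six-membered aromatic ring leaves this position, yet this assay gives only a step within the scatter (a 1.1-fold lower number from compound 3 to compound 4 (0.05 log units; within the scatter)). The comparisons with the ring-bearing compounds read the same (a 1.3-fold higher number from compound 2 to compound 4 (0.10 log units; within the scatter) and a 1.2-fold lower number from compound 1 to compound 4 (0.08 log units; within the scatter)), so among these four compounds a ring at this position is not needed for a number in this range. No measurement at hand explains this result.

From the compounds shown here alone, it remains open whether any group on this carbon can move the number beyond the scatter. An amine or a carboxylic acid at the end of a longer chain would test this, and neither appears among the compounds shown.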